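The source may hold more compounds than are shown below. What is called first, only, known or untested is meant among the compounds shown, and "the series" means these compounds.

Measured compounds:
compound 1 `CC(C)(C)c1ccc(Oc2ccc3c(NCCCNCc4ccco4)ccnc3c2)cc1` — 3100 nM
compound 2 `COc1cccc(CNCCCNc2ccnc3cc(-c4ccc(C(C)(C)C)cc4)ccc23)c1O` — 690 nM
compound 3 `COc1cccc(Oc2ccc3c(NCCCNCc4cccc(OC)c4O)ccnc3c2)c1` — 5300 nM

In an ADME assay on HepG2 cells (Homo sapiens) for cytotoxicity, read by luminescence, CellTiter-Glo and ATP content, with a stated time of 72 h (a higher number here means that more compound is needed for the effect, a lower number that less compound is needed), compound 1 sits second highest of the three numbers. Compound 3 is its nearest neighbour, and the two values lie within the usual scatter of each other, so nothing can be said about their order. Compound 2 gives the lowest number of the three, and its gap to compound 1 lies beyond the scatter.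

Compound 4 `CN(C)c1cccc(Oc2ccc3c(NCCCNCc4ccco4)ccnc3c2)c1` has not yet been measured. It differs from compound 1 in one place: 3-(dimethylamino)phenyl in place of 4-(tert-butyl)phenyl on an oxygen on an aromatic ring. Among the compounds with values here, the only step measured so far, a 7.7-fold higher number from compound 2 to compound 3 (0.89 log units; beyond the scatter), concerns a different position on the shared core, where the 4-(tert-butyl)phenyl was replaced by a 3-methoxyphenoxy. Within the data shown here, it bears on the present change only loosely, but it is the sole guide available. Compound 1 and compound 3, which both carry a phenoxy group on the core, give numbers within the scatter of each other, so the change to another phenoxy group is expected to move the number little, if at all, in this assay.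

Compound 4 is therefore estimated at 4000 nM, with a range from 1500 nM to 11000 nM, a step of a 1.3-fold higher number from compound 1 to compound 4 (0.11 log units; within the scatter) that is expected to stay within the scatter.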

Compound 4, half-maximal effective concentration: 16000 nM
Compound 4: the middle estimate sits 4.0-fold (0.60 log units) below what was measured; measured number above the stated range.
By their numbers in this assay, from the lowest: compound 2; then compounds 1 and 3 (each within the scatter of the next); then compound 4.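

The group on an oxygen on an aromatic ring is not a neutral spectator in this assay: with the rest of compound 1 left unchanged, putting 3-(dimethylamino)phenyl in place of 4-(tert-butyl)phenyl gives a 5.2-fold higher number from compound 1 to compound 4 (0.71 log units; beyond the scatter), so more compound is needed for the effect. Within the data shown here, the earlier compounds offered no pair differing only at this place, and this step is the first direct reading of it. The two groups share one six-membered aromatic ring of carbon only, while the entering group has one heavy atom fewer, a nitrogen and one hydrogen-bond acceptor, and nothing available explains why the number moves.

The change swaps two things at once, the 4-(tert-butyl) group for a 3-(dimethylamino) group, so the compounds shown cannot say how much of the step belongs to losing the first or gaining the second. On these data alone, a plain phenyl, a 3-(tert-butyl)phenyl or a 4-(dimethylamino)phenyl at the same place would be needed to pull these apart, and whether the step holds with a different chain on the shared core also remains open.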